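Methoxy to hydroxy: a single step from compound 1

The source may hold more compounds than are shown below. What is called first, only, known or untested is meant among the compounds shown, and "the series" means these compounds.

Compound 1 `COc1cc(-c2nn(-c3ccc(NC(=O)Nc4cc(C(F)(F)F)cc(C(F)(F)F)c4)cc3)cc2-c2ccncc2)ccc1Cl` gives 1880 nM in a functional assay on MDA-MB-435 cells (Homo sapiens) for antiproliferative activity, read by sulforhodamine B assay, with a stated time of 48 h (on this read-out lower numbers stand for stronger inhibition and higher numbers for weaker inhibition), the lowest of the two numbers measured; compound 2 `COc1cc(-c2nn(-c3ccc(NC(=O)c4ccc(Cl)c(Cl)c4)cc3)cc2-c2ccncc2)ccc1Cl` gives 7130 nM in this assay. Compound 3 `COc1cc(-c2nn(-c3ccc(NC(=O)c4cc(Cl)cc(Cl)c4)cc3)cc2-c2ccncc2)ccc1Cl` reaches only the limit > 100000 nM in this assay (the limit of > 100000 nM in this assay, at which 1 of the 3 values shown sits). Among the compounds with values here, the one measured step, an at least 14-fold higher number from compound 2 to compound 3 (1.14 log units; beyond the scatter), concerns the ring on the carbonyl carbon and not the place altered here. Compound 4 `O=C(Nc1ccc(-n2cc(-c3ccncc3)c(-c3ccc(Cl)c(O)c3)n2)cc1)Nc1cc(C(F)(F)F)cc(C(F)(F)F)c1` differs from compound 1 by hydrogen in place of methyl on an oxygen on an aromatic ring, methoxy to hydroxy on the 4-chloro-3-methoxyphenyl ring. Within the data shown here, no measured step bears on this change, so no step beyond the scatter is expected in either direction in this assay. Compound 4 is therefore estimated at 2500 nM in this assay, with a range from 800 nM to 8000 nM, which is expected to mean a 1.3-fold higher number from compound 1 to compound 4 (0.12 log units; within the scatter).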

Compound 4, half-maximal inhibitory concentration: 1770 nM
Beside the measured number, compound 4's estimate is 1.4-fold (0.15 log units) above it, within the range that was stated.
By their numbers in this assay, from the lowest: compounds 4 and 1 (each within the scatter of the next); then compound 2. At a limit, above all of these: compound 3.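

Within the data shown here, with a 1.1-fold lower number from compound 1 to compound 4 (0.03 log units; within the scatter) in this assay, methoxy to hydroxy on the 4-chloro-3-methoxyphenyl ring is tolerated in this single pair, the first measured change at this place. In the setting of compound 1, the methyl on this oxygen is therefore not needed to keep the reading. Nothing measured here accounts for this outcome. Still open, on these data alone, is how an ethyl group, a longer chain or an amine in place of the hydroxy would read. Also open, as far as these compounds go, is whether hydroxy is tolerated equally in the setting of compound 2.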